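The source may hold more compounds than are shown below. What is called first, only, known or untested is meant among the compounds shown, and "the series" means these compounds.

Measured in a functional assay on SK-HEP1 cells (Homo sapiens) for antiproliferative activity, read by sulforhodamine B assay, with a stated time of 72 h; on this read-out lower numbers stand for stronger inhibition and higher numbers for weaker inhibition:
compound 1 `COc1ncc(-c2ccc3ncc(C(=O)NCc4ccncc4)n3c2)cc1NS(=O)(=O)c1ccc(F)cc1F`, 980 nM
compound 2 `CCOC(=O)c1cc2cc(-c3cnc(OC)c(NS(=O)(=O)c4ccc(F)cc4)c3)ccc2[nH]1`, 300 nM

Compound 1 stands at the higher of the two numbers; compound 2 sits at a lower number, a gap beyond the usual scatter. Compound 3 `COc1ncc(-c2ccc3ncc(C(=O)O)n3c2)cc1NS(=O)(=O)c1ccc(F)cc1F` has not yet been measured. It differs from compound 1 in one place: hydroxy in place of ((pyridin-4-yl)methyl)amino on a carbonyl carbon. For the measured compounds named here, no measured pair shows this same change, so the step can only be estimated. The expected step in this assay is a rise in the number, a 3.1-fold higher number from compound 1 to compound 3 (0.49 log units; beyond the scatter), beyond the scatter. For compound 3 the estimate is 3000 nM, in the range 1000 nM to 10000 nM.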

Compound 3, half-maximal inhibitory concentration: 750 nM
The estimate for compound 3 lay 4.0-fold (0.60 log units) above the measured number; measured number below the stated range.
By their numbers in this assay, from the lowest: compound 2; then compounds 3 and 1 (each within the scatter of the next).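

Swapping ((pyridin-4-yl)methyl)amino for hydroxy on the carbonyl carbon gives, in this assay, a 1.3-fold lower number from compound 1 to compound 3 (0.12 log units; within the scatter) and leaves no readable difference. At this position, the six-membered aromatic ring and the amide nitrogen of compound 1 are therefore not required to hold this level of antiproliferative activity, at least in this pair. No supporting data bear on the reason for this flat step.

Going by these compounds, whether a primary carboxamide or a methyl ester on the same carbonyl carbon would stay at this level remains open. So does the effect of a longer chain between the amide nitrogen and the ring.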